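Chloro to methyl on the 2-chloro-4,6-dimethylphenyl group

The source may report more compounds than this note shows. Statements on the series, on what has been measured and on what is new or still open speak of the compounds shown alone.

Three compounds of the series have numbers in an assay for displacement of a labelled ligand from corticotropin-releasing factor receptor 1 (Homo sapiens); on this read-out higher numbers stand for weaker inhibition and lower numbers for stronger inhibition. Compound 1 `CCCN(CC1CC1)C(=O)c1sc(Nc2c(Cl)cc(Cl)cc2Cl)nc1CC` gives 11000 nM. Compound 2 `CCCN(Cc1sc(Nc2c(C)cc(C)cc2Br)nc1C(F)(F)F)CC1CC1` gives 21 nM, and compound 3 `CCCN(Cc1sc(Nc2c(C)cc(C)cc2Cl)nc1C(F)(F)F)CC1CC1` gives 23 nM. Compound 3 stands second highest of the three; its nearest neighbour is compound 2, separated by a gap within the scatter, while compound 1 lies far higher, its number standing for far weaker inhibition than that of compound 3.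

Compound 4 `CCCN(Cc1sc(Nc2c(C)cc(C)cc2C)nc1C(F)(F)F)CC1CC1` has not yet been measured. It differs from compound 3 in one place: methyl in place of chloro on an aromatic carbon. For the measured compounds named here, the only measured step that touches this position is the halogen swap a 1.1-fold higher number from compound 2 to compound 3 (0.04 log units; within the scatter), which stayed within the scatter. Going by the values given here, no measured step leads to a methyl at this place, and compound 1 differs in too many places to bear on it. A chloro to methyl exchange here is therefore expected to change the number little, if at all, with an estimated 1.5-fold higher number from compound 3 to compound 4 (0.18 log units; within the scatter). For compound 4 the expected value in this assay is 35 nM, between 12 nM and 110 nM.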

Compound 4, inhibition constant: 60 nM
The estimate for compound 4 lay 1.7-fold (0.23 log units) below the measured number; the range from low to high includes it.
By their numbers in this assay, from the lowest: compounds 2 and 3 (each within the scatter of the next); then compound 4; then compound 1.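

Methyl in place of chloro gives a 2.6-fold higher number from compound 3 to compound 4 (0.42 log units; beyond the scatter) and methyl in place of bromo gives a 2.9-fold higher number from compound 2 to compound 4 (0.46 log units; beyond the scatter) in this assay and both steps lie beyond the scatter, while the swap of bromo for chloro gave only a 1.1-fold higher number from compound 2 to compound 3 (0.04 log units; within the scatter) and stayed within it. This position on the aromatic ring therefore tells methyl apart from the two halogens, by a modest margin, in a way the halogen pair alone could not show. Nothing available here accounts for this difference between methyl and the halogens.

Open, on these data alone, is what fluoro, methoxy, a nitrile or plain hydrogen would give at this place on the ring. Also open, as far as these compounds go, is whether the step from chloro to methyl keeps its size when an ethyl group stands in place of trifluoromethyl on the shared core.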